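Ring size of the cyclic amine: compound 3

This account rests on a few compounds, and the source may have more. Where it says the series, first, only, none or still open, it means among the compounds named here.

Going by the values given here, compound 2 `Fc1ccccc1Cn1nc(-c2ncc(F)c(N3CCCC3)n2)cc1-c1ccon1` holds the lowest of the two numbers measured so far in an assay on a protein complex for activation of soluble guanylate cyclase (Homo sapiens), read by cGMP accumulation, in the presence of a further agent that is not named here (a higher number here means that more compound is needed for the effect, a lower number that less compound is needed), where compound 2 gives 83 nM. Its nearest neighbour, compound 1 `Fc1ccccc1Cn1nc(-c2ncc(F)c(OCC3CC3)n2)cc1-c1ccon1`, gives 2300 nM in this assay. Among the compounds with values here, the one measured step, a 28-fold lower number from compound 1 to compound 2 (1.44 log units; beyond the scatter), is large and well beyond the scatter.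

Compound 3 `Fc1ccccc1Cn1nc(-c2ncc(F)c(N3CCCCC3)n2)cc1-c1ccon1` differs from compound 2 in a single place: piperidin-1-yl in place of pyrrolidin-1-yl on an aromatic carbon. Within the data shown here, no measured step bears directly on this change. The step from compound 1 to compound 2 replaced an ether by a cyclic amine, whereas here the cyclic amine is kept and only its ring size changes, so that step is a weak guide. Because compound 2 gives 83 nM with the cyclic amine already in place, compound 3 is expected to remain close to that number, with a step of a 1.4-fold higher number from compound 2 to compound 3 (0.16 log units; within the scatter) expected, within the scatter. The estimate for compound 3 is 120 nM, with a range of 40 nM to 400 nM.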

Compound 3, half-maximal effective concentration: 27 nM
Estimate against measurement, compound 3: 4.4-fold (0.65 log units) above, and the stated range ends above it.
By their numbers in this assay, from the lowest: compound 3; then compound 2; then compound 1.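

Ring size alone matters at this position, the aromatic carbon next to the ring nitrogen and ortho to a fluoro group: in this assay there is a 3.1-fold lower number from compound 2 to compound 3 (0.49 log units; beyond the scatter), although the change only enlarges the cyclic amine from pyrrolidin-1-yl to piperidin-1-yl. Going by these compounds alone, the gain seen on leaving the ether is therefore not fixed across cyclic amines, and an 85-fold lower number from compound 1 to compound 3 (1.93 log units; beyond the scatter) is the largest step so far, leaving compound 3 with the lowest number of the three. The data offer no explanation for the ring-size effect.

On these data alone, two ring sizes define no trend, so it remains open whether azepan-1-yl would continue the direction from pyrrolidin-1-yl to piperidin-1-yl. Also open, as far as these compounds go, is whether a ring hetero atom, as in morpholin-4-yl, or an open-chain dimethylamino group would be tolerated here.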